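Carbonyl substituent variation: compound 2 to compound 4

This account rests on a few compounds, and the source may have more. Where it says the series, first, only, none or still open, it means among the compounds named here.

Of the compounds shown here, three have been measured in a functional assay on Shh Light II cells (Mus musculus) for inhibition, read by a luciferase reporter; on this read-out lower numbers stand for stronger inhibition and higher numbers for weaker inhibition. Compound 1 `Cc1ccccc1NC(=O)N1CCC(c2nc(-c3ccc4ccccc4n3)no2)CC1` gives 440 nM, compound 3 `CC(C)c1ccccc1NC(=O)N1CCC(c2nc(-c3ccc4ccccc4n3)no2)CC1` gives 480 nM, and compound 2 `O=C(CC1CCCCCC1)N1CCC(c2nc(-c3ccc4ccccc4n3)no2)CC1` gives 840 nM. Compound 2 thus carries the highest of the three numbers, yet its steps to compound 1 and to compound 3 both lie within the scatter, so no ordering among the three is established.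

Compound 4 `O=C(OCc1ccccc1)N1CCC(c2nc(-c3ccc4ccccc4n3)no2)CC1` is the next member. Relative to compound 2 the change is benzyloxy in place of cycloheptylmethyl on a carbonyl carbon. Two measured steps alter the same carbonyl carbon: a 1.9-fold higher number from compound 1 to compound 2 (0.28 log units; within the scatter) and a 1.8-fold lower number from compound 2 to compound 3 (0.24 log units; within the scatter). Each exchanges one substituent on that carbonyl for a rather different one, and each remains within the scatter. On this basis the step is expected to be a 1.4-fold lower number from compound 2 to compound 4 (0.15 log units; within the scatter), with no clear direction. Compound 4 is accordingly estimated at 600 nM, within a range from 250 nM to 1500 nM.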

Compound 4, half-maximal inhibitory concentration: > 2500 nM
Compound 4: only a limit was reported (the forecaster's own chance of this, stated with the estimate: 5%); at least 4.1-fold (0.61 log units) between middle value and limit.
By their numbers in this assay, from the lowest: compounds 1, 3 and 2 (each within the scatter of the next). At a limit, above all of these: compound 4.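

In this assay compound 4 carries only a limit, not a number: the limit of > 2500 nM in this assay, at which 1 of the 4 values shown sits.

The carbonyl position, where the earlier exchanges all stayed within the scatter, now gives steps beyond it: an at least 2.9-fold higher number from compound 2 to compound 4 (0.47 log units; beyond the scatter), together with an at least 5.2-fold higher number from compound 3 to compound 4 (0.71 log units; beyond the scatter) and an at least 5.6-fold higher number from compound 1 to compound 4 (0.75 log units; beyond the scatter). Benzyloxy is thus the first group on this carbonyl carbon to separate from the others, while cycloheptylmethyl, (2-methylphenyl)amino and (2-isopropylphenyl)amino remain within the scatter of one another.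

The compounds shown do not separate the oxygen of benzyloxy from its aromatic ring, and a 2-phenylethyl or cycloheptyloxy group on the same carbonyl carbon would bear on that. As far as these compounds go, the full size of all three steps also stays open, since each rests on a limit.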